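The source may report more compounds than this note shows. Statements on the series, on what has been measured and on what is new or still open speak of the compounds shown alone.

Measured so far in a functional assay on MCF7 cells (Homo sapiens) for cytotoxicity, with a stated time of 48 h; on this read-out higher numbers stand for weaker inhibition and lower numbers for stronger inhibition:

compound 1 `COc1cc(OC)c(C(=O)/C=C/c2ccccc2OC)c(OC)c1`: 8900 nM
compound 2 `COc1cccc(/C=C/C(=O)c2c(OC)cc(OC)cc2OC)c1`: 9400 nM
compound 3 `COc1cc(OC)c(C(=O)/C=C/c2ccccc2)c(OC)c1`: 9400 nM

Compound 1 gives the lowest of the three numbers, but this means little: a 1.1-fold higher number from compound 1 to compound 2 (0.02 log units; within the scatter) and a 1.1-fold higher number from compound 1 to compound 3 (0.02 log units; within the scatter) are both within the scatter, as is no change at the digits printed from compound 2 to compound 3 (within the scatter). All three compounds therefore read the same within the precision of this assay, and the changes tried so far, on the ring at the chain end, leave the read-out where it was.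

Compound 4 `COc1cc(O)c(C(=O)/C=C/c2ccccc2OC)c(OC)c1` differs from compound 1 in one place: hydrogen in place of methyl on an oxygen on an aromatic ring. Among the compounds with values here, no measured step touches this position. The three steps known all concern the ring at the far end of the chain, not an oxygen on the shared core, and each of them was within the scatter. Within the data shown here, there is thus no basis in the data for expecting a step beyond the scatter in this assay, nor for a direction; the only thing the measured steps show is that this small set has so far been insensitive to single changes of a methoxy group.

The expectation for compound 4 is therefore essentially the value of compound 1, with a wide range to allow for an untested kind of change: compound 4 is estimated at 9000 nM, between 3000 nM and 27000 nM, which means an expected step of a 1.0-fold higher number from compound 1 to compound 4 (0.00 log units; within the scatter).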

Compound 4, half-maximal inhibitory concentration: 10500 nM
Compound 4: the middle estimate sits 1.2-fold (0.07 log units) below what was measured; low and high end bracket the measured number.
By their numbers in this assay, from the lowest: compounds 1, 2, 3 and 4 (each within the scatter of the next).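

In this assay, methoxy to hydroxy on the shared core gives a 1.2-fold higher number from compound 1 to compound 4 (0.07 log units; within the scatter) and so shows that this oxygen on an aromatic ring can lose its methyl without a difference beyond the scatter. The earlier steps shown here covered only the ring at the far end of the chain, so the flat read-out now extends to one position on the core as well, and this single change from methyl to hydrogen adds no separation to the series. No supporting measurement is available to explain why this position gives a flat read-out.

The compounds shown leave open whether any single change can move this series beyond the scatter, and whether the other methoxy groups on the shared core behave as this one does. A longer chain on this same oxygen, or an amine or a carboxylic acid on the ring at the far end of the chain, would test whether the read-out stays flat with groups unlike those compared so far.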